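Fluoro in place of chloro in a cytotoxicity series

The compounds below may be only part of what the source reports. "The series", "measured", "known", "first", "only" and "open" are said of these compounds alone.

The compounds measured in an ADME assay on Vero 76 cells (Chlorocebus sabaeus) for cytotoxicity, read by MTT assay, with a stated time of 96 h (on this read-out lower numbers stand for higher toxicity in this test and higher numbers for lower toxicity in this test), are these:

Compound 1 `NS(=O)(=O)c1ccc(N2N=C(c3ccc(Oc4ccccc4)cc3)CC2c2cccc(F)c2)cc1` gives 28000 nM
Compound 2 `NS(=O)(=O)c1ccc(N2N=C(c3ccc(OCc4ccccc4)cc3)CC2c2ccccc2F)cc1` gives > 100000 nM as a limit of the assay
Compound 3 `NS(=O)(=O)c1ccc(N2N=C(c3ccc(Oc4ccccc4)cc3)CC2c2ccccc2Cl)cc1` gives 29000 nM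

Compound 3 and compound 1 lie within the scatter of each other, so neither can be placed ahead. Compound 2 stands at a limit (the limit of > 100000 nM in this assay, at which 1 of the 3 values shown sits).

Compound 4 `NS(=O)(=O)c1ccc(N2N=C(c3ccc(Oc4ccccc4)cc3)CC2c2ccccc2F)cc1` is not yet measured. It departs from compound 3 in one place (fluoro in place of chloro on an aromatic carbon), with fluoro in place of chloro on an aromatic carbon, ortho to a large group. The same difference reads 2-chlorophenyl to 2-fluorophenyl.

Going by the values given here, the one measured step bearing on this change is a 1.0-fold higher number from compound 1 to compound 3 (0.02 log units; within the scatter), and it stays within the scatter. On that basis, the expected step is a 1.0-fold higher number from compound 3 to compound 4 (0.01 log units; within the scatter), with nothing beyond the scatter foreseen in this assay. Compound 4 is estimated at 30000 nM (expected range 14000 nM to 65000 nM).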

Compound 4, half-maximal cytotoxic concentration: 96000 nM
For compound 4 the middle estimate is 3.2-fold (0.51 log units) below the measured one, and the stated range ends below it.
By their numbers in this assay, from the lowest: compounds 1 and 3 (each within the scatter of the next); then compound 4. At a limit, above all of these: compound 2.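

In this assay, fluoro in place of chloro on this aromatic carbon, ortho to a large group, now matters: the step is a 3.3-fold higher number from compound 3 to compound 4 (0.52 log units; beyond the scatter), although 2-chlorophenyl in place of 3-fluorophenyl gave a 1.0-fold higher number from compound 1 to compound 3 (0.02 log units; within the scatter). Fluoro itself is not enough, since moving to 2-fluorophenyl from 3-fluorophenyl gives a 3.4-fold higher number from compound 1 to compound 4 (0.54 log units; beyond the scatter), so in these compounds the higher number goes only with the 2-fluorophenyl group, and both steps are modest. Phenyl in place of benzyl on an oxygen on an aromatic ring gives an at least 1.0-fold lower number from compound 2 to compound 4 (0.01 log units; that floor lies within the scatter), a step that is only a floor, because compound 2 stands at a limit: the limit of > 100000 nM in this assay, at which 1 of the 4 values shown sits.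

The compounds shown leave open how a methoxy group or an amine at this place on the phenyl ring would read. They also give no measured property that could account for the difference between fluoro and chloro.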